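Swapping a ring nitrogen substituent for a propanoyl group

A few compounds are considered here, and "the series" means these few. Any claim that something is new, unique, unknown or untested is made for them only; others in the source may bear on it.

Three compounds share one core and were tested in an assay on HEK293 cells for negative allosteric modulation of metabotropic glutamate receptor 5 (Homo sapiens), read by FLIPR, with a stated time of 1 h; a lower number here means a stronger inhibitor, a higher number a weaker inhibitor. Compound 1 `CCN1CCc2nc(C#Cc3ccccc3)sc2C1` gives 1200 nM, and compound 2 `CC(C)CN1CCc2nc(C#Cc3ccccc3)sc2C1` gives 650 nM; the step of a 1.8-fold lower number from compound 1 to compound 2 (0.27 log units; within the scatter). Compound 3 `C(#Cc1nc2c(s1)CN(C1CCCCC1)CC2)c1ccccc1` returns only a limit of the assay, > 10000 nM, so it stands at the weak end of the three. The steps of an at least 8.3-fold higher number from compound 1 to compound 3 (0.92 log units; beyond the scatter) and an at least 15-fold higher number from compound 2 to compound 3 (1.18 log units; beyond the scatter) both point the same way, matching (the limit of > 10000 nM in this assay, at which 1 of the 3 values shown sits). Compound 4 `CCC(=O)N1CCc2nc(C#Cc3ccccc3)sc2C1` changes compound 3 by propanoyl in place of cyclohexyl on an amine nitrogen in a ring. Within the data shown here, since the cyclohexyl carried the weakening in both measured steps, removing it is expected to recover some strength, though no measured step shows a propanoyl group. Compound 4 is therefore estimated at 3000 nM, between 800 nM and 10000 nM, a step of an at least 3.3-fold lower number from compound 3 to compound 4 (0.52 log units; beyond the scatter).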

Compound 4, half-maximal inhibitory concentration: 38 nM
Compound 4: the middle estimate sits 79-fold (1.90 log units) above what was measured; the whole stated range lies above it.
By their numbers in this assay, from the lowest: compound 4; then compounds 2 and 1 (each within the scatter of the next). At a limit, above all of these: compound 3.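

Propanoyl on the amine nitrogen in a ring gives a 32-fold lower number from compound 1 to compound 4 (1.50 log units; beyond the scatter) and a 17-fold lower number from compound 2 to compound 4 (1.23 log units; beyond the scatter), so this position allows far more strength than the ethyl and isobutyl groups showed. The change also gives an at least 260-fold lower number from compound 3 to compound 4 (2.42 log units; beyond the scatter), but compound 3 stands at a limit, so this step is only a bound: the limit of > 10000 nM in this assay, at which 1 of the 4 values shown sits.

Propanoyl is the first group here with a carbonyl, but these compounds cannot show whether the carbonyl itself matters. An acetyl group, a longer acyl chain or a methoxyethyl chain on this nitrogen would help to settle that.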